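Thiosemicarbazone series: cyclohexylmethoxy in place of fluoro

A few compounds are considered here, and "the series" means these few. Any claim that something is new, unique, unknown or untested is made for them only; others in the source may bear on it.

Working notes on the series. Compound 1 `CCCCn1cc(/C=N/NC(N)=S)c2cccc(C)c21` reaches only a limit in a toxicity assay on THP-1 cells (Homo sapiens) for cytotoxicity, read by MTT assay, with a stated time of 72 h (on this read-out lower numbers stand for an effect already at smaller amounts and higher numbers for an effect only at larger amounts of compound), > 200000 nM, which sits at the limit of > 200000 nM in this assay, at which 1 of the 2 values shown sits. Within the data shown here, compound 2 `NC(=S)N/N=C/c1ccc(F)c2ccccc12` gives 39000 nM in this assay, the only number among the values shown so far. Compound 3 `NC(=S)N/N=C/c1ccc(OCC2CCCCC2)c2ccccc12` carries the change (cyclohexylmethoxy in place of fluoro on an aromatic carbon), cyclohexylmethoxy in place of fluoro on an aromatic carbon. Among the measured compounds shown here, no step between measured compounds is available for this change; a moderate shift toward an effect at smaller amounts in this assay is expected, estimated as a 2.6-fold lower number from compound 2 to compound 3 (0.41 log units; beyond the scatter). Compound 3 is estimated at 15000 nM, within 4000 nM to 60000 nM.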

Compound 3, half-maximal effective concentration: 150000 nM
Estimate against measurement, compound 3: 10-fold (1.00 log units) below; the measured number lies above the stated range.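

At this aromatic carbon, cyclohexylmethoxy in place of fluoro gives a 3.8-fold higher number from compound 2 to compound 3 (0.59 log units; beyond the scatter) in this assay, so the position responds to this change, toward an effect only at larger amounts. The read-out is therefore not set by the shared core alone. The new number moves toward the limit of this assay, which remains a limit and not a number: the limit of > 200000 nM in this assay, at which 1 of the 3 values shown sits.

A single step cannot separate the contribution of the cyclohexyl ring from that of the ether oxygen. Methoxy or an amine on this carbon would bear on that question.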